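Bromo added to the aryl ring of compound 3

A few compounds are considered here, and "the series" means these few. Any claim that something is new, unique, unknown or untested is made for them only; others in the source may bear on it.

Measured in a functional assay on DU-145 cells (Homo sapiens) for cytotoxicity, read by trypan blue exclusion, with a stated time of 96 h (on this read-out lower numbers stand for stronger inhibition and higher numbers for weaker inhibition), so far:
- compound 1 `COc1cc(OC)c(/C=C/S(=O)(=O)Nc2ccc(OC)c(N)c2)c(OC)c1` gives 5 nM
- compound 2 `COC(=O)C(Nc1cc(NS(=O)(=O)/C=C/c2c(OC)cc(OC)cc2OC)ccc1OC)c1ccc(Br)cc1` gives 7500 nM
- compound 3 `COc1cc(OC)c(/C=C/S(=O)(=O)Nc2ccc(OC)c(NC(C(=O)O)c3ccccc3)c2)c(OC)c1` gives 75 nM

Compound 3 stands second highest of the three numbers, reached by a 15-fold higher number from compound 1 to compound 3 (1.18 log units; beyond the scatter) and by a 100-fold lower number from compound 2 to compound 3 (2.00 log units; beyond the scatter) from the other side.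

The next compound, compound 4 `COc1cc(OC)c(/C=C/S(=O)(=O)Nc2ccc(OC)c(NC(C(=O)O)c3ccc(Br)cc3)c2)c(OC)c1`, differs from compound 3 by bromo in place of hydrogen on an aromatic carbon and has bromo in place of hydrogen on an aromatic carbon, para to a large group.

Going by the values given here, no measured step isolates this change. Two steps involve the 4-bromophenyl group, a 1500-fold higher number from compound 1 to compound 2 (3.18 log units; beyond the scatter) and a 100-fold lower number from compound 2 to compound 3 (2.00 log units; beyond the scatter), but both also involve the methoxycarbonyl group, which compound 4 does not carry. Compound 4 keeps the carboxy group of compound 3, so neither large step can be assigned to bromo alone, and a step of that size is not expected in this assay here.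

a 1.3-fold higher number from compound 3 to compound 4 (0.12 log units; within the scatter) is the step expected, with none beyond the scatter as the likeliest outcome. In this assay the estimated value for compound 4 is 100 nM with 30 nM to 400 nM as the expected range.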

Compound 4, half-maximal inhibitory concentration: 250 nM
The estimate for compound 4 lay 2.5-fold (0.40 log units) below the measured number; the range from low to high includes it.
By their numbers in this assay, from the lowest: compound 1; then compound 3; then compound 4; then compound 2.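

In this assay, going by these compounds alone, bromo on the aromatic carbon para to a large group, with the carboxy group kept, gives a 3.3-fold higher number from compound 3 to compound 4 (0.52 log units; beyond the scatter) as a step; this is the first reading of the change on its own, and it is modest. With bromo held constant, hydrogen in place of methyl on the oxygen next to a carbonyl group gives a 30-fold lower number from compound 2 to compound 4 (1.48 log units; beyond the scatter) as a much larger step, while the whole (4-bromophenyl)(carboxy)methyl group on the nitrogen gives a 50-fold higher number from compound 1 to compound 4 (1.70 log units; beyond the scatter) as its step against the unsubstituted amine of compound 1. Nothing at hand explains the bromo step.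

On these data alone, whether fluoro, chloro or methoxy at this ring position would follow bromo remains open. So does the effect of the methoxycarbonyl group on the unsubstituted phenyl ring, or of a primary amide in its place.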